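Adding a methoxy group: from compound 3 to compound 4

The source may report more compounds than this note shows. Statements on the series, on what has been measured and on what is new or still open speak of the compounds shown alone.

Compound 1, `COc1ccc(-c2cn(-c3ccc(OC(F)(F)F)cc3)nn2)cc1OC`, gives a value in a functional assay on MDA-MB-231 cells (Homo sapiens) for cytotoxicity, read by MTT assay (a higher number here means a weaker inhibitor, a lower number a stronger inhibitor), that is only a limit of the assay, > 1000 nM.
Compound 2, `COc1cc(-c2cn(-c3ccc(Oc4ccccc4)cc3)nn2)cc(OC)c1OC`, gives 10000 nM in this assay.
Compound 3, `COc1cc(OC)cc(-c2cn(-c3ccc(OC(F)(F)F)cc3)nn2)c1`, gives only a limit, > 1000 nM in this assay.

Compound 3 therefore stands at a limit rather than at a number, and it shares this with compound 1, as the evidence shows: the limit of > 1000 nM in this assay, at which 2 of the 3 values shown sit. Only compound 2 gives a measured number, and that number is a weak one.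

Compound 4, `COc1cc(-c2cn(-c3ccc(OC(F)(F)F)cc3)nn2)cc(OC)c1OC`, has not yet been tested. It differs from compound 3 by methoxy in place of hydrogen on an aromatic carbon. No change between two measured compounds is available for comparison, so the size of the step cannot be read off from the data. Compound 4 carries the same set of methoxy groups as compound 2, but a trifluoromethoxy group where the other carries a phenoxy group; compound 2 gives 10000 nM, so a weak result is expected. Compound 4 is estimated to give 5000 nM in this assay, between 1500 nM and 30000 nM. This means an expected step that the limit leaves unreadable from compound 3 to compound 4, with a fair chance that the assay again reports only a limit.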

Compound 4, half-maximal inhibitory concentration: > 10000 nM
Compound 4 was reported as a limit (the forecaster's own chance of this, stated with the estimate: 40%); middle value at least 2.0-fold (0.30 log units) away from the limit.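

In this assay compound 4 gives only a limit of the assay, > 10000 nM. A methoxy group at this place, ortho to two methoxy groups and para to a large group, therefore yields no measured number, and the steps to compound 4 from compound 3 and from compound 1 cannot be read, as both ends of each are limits. Trifluoromethyl in place of phenyl on an oxygen gives a number no lower from compound 2 to compound 4 (the limit leaves the size open), so with the methoxy groups kept the same, this exchange shows no gain in this assay.

On these data alone, the true strengths of compound 1, compound 3 and compound 4 stay open, as does the real effect of the added methoxy group. Also open, as far as these compounds go, is whether a hydroxyl group or an amine at this place, or a carboxylic acid in place of the trifluoromethoxy group, would give a measured number in this assay.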